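Adding a Methoxy Group: Expected Cytotoxicity of Compound 4

A few compounds are considered here, and "the series" means these few. Any claim that something is new, unique, unknown or untested is made for them only; others in the source may bear on it.

Measured so far:
Compound 1, `CC(=O)Nc1ccc(O)c(C(=O)/C=C/c2ccccc2)c1`, gives 85500 nM in an ADME assay on THP-1 cells (Homo sapiens) for cytotoxicity, read by flow cytometry and propidium iodide staining, with a stated time of 72 h; a lower number here means a stronger inhibitor, a higher number a weaker inhibitor.
Compound 2, `COc1cccc(/C=C/C(=O)c2cc(NC(C)=O)ccc2O)c1`, gives 93700 nM in this assay.
Compound 3, `COc1c(-c2ccccc2)oc2ccc(N)cc2c1=O`, gives 74000 nM in this assay.

Compound 1 and compound 2 share a core and differ in a single place: methoxy in place of hydrogen on an aromatic carbon. The step in this assay is a 1.1-fold higher number from compound 1 to compound 2 (0.04 log units; within the scatter), so the added methoxy group left the read-out essentially where it was. Compound 3 is built on a different core; the difference between the two cores is not broken down here. The three measured values all lie within the usual scatter of one another, so no one of them can be called stronger or weaker than the others.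

Compound 4, `COc1ccc(-c2oc3ccc(N)cc3c(=O)c2OC)cc1`, has not yet been measured. It differs from compound 3 in one place: methoxy in place of hydrogen on an aromatic carbon. Going by the values given here, this is the same kind of change as the one from compound 1 to compound 2, but not the same change: in compound 2 the methoxy sits meta to a large group, whereas in compound 4 it sits para to a large group. Among the compounds with values here, the step expected from compound 3 to compound 4 is a 1.1-fold higher number from compound 3 to compound 4 (0.03 log units; within the scatter), which rests on the observation that the only methoxy step seen so far, a 1.1-fold higher number from compound 1 to compound 2 (0.04 log units; within the scatter), stayed within the scatter. Compound 4 is therefore expected to give 80000 nM in this assay, with a likely range from 40000 nM to 160000 nM.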

Compound 4, half-maximal inhibitory concentration: 21000 nM
For compound 4 the middle estimate is 3.8-fold (0.58 log units) above the measured one, and the stated range ends above it.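

In this assay, methoxy in place of hydrogen on an aromatic carbon gives a 3.5-fold lower number from compound 3 to compound 4 (0.55 log units; beyond the scatter), so on the core of compound 3 this small addition goes with a stronger inhibitor, a real shift rather than scatter. Set beside the earlier step, the same kind of change does not carry over with the same size from one core to the other: the same change on two cores in this assay, a 1.1-fold higher number (0.04 log units; within the scatter) from compound 1 to compound 2 and a 3.5-fold lower number (0.55 log units; beyond the scatter) from compound 3 to compound 4, 3.9-fold (0.59 log units) apart, beyond the scatter of two such steps. Going by these compounds alone, this rests on only two pairs, and the methoxy does not occupy the same position in both, since in compound 4 it is para to a large group while in compound 2 it lies elsewhere, so the data cannot say whether the core, the position or both account for the gap.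

The compounds shown leave open whether the shift belongs to methoxy itself or would also appear with another group at the same place on the core of compound 3, such as a hydroxyl, a fluorine or a longer chain like ethoxy. They also leave open what a methoxy would do on the core of compound 3 at the position it holds in compound 2, the comparison that would begin to separate core from position.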